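A few compounds are considered here, and "the series" means these few. Any claim that something is new, unique, unknown or untested is made for them only; others in the source may bear on it.

Compound 1 `Cc1ccc(-[n+]2noc([O-])c2CN2CCN(c3cccc(Cl)c3)CC2)cc1` was tested in an ADME assay on HEL cells (Homo sapiens) for cytotoxicity (on this read-out higher numbers stand for lower toxicity in this test and lower numbers for higher toxicity in this test), where compound 1 gives 38.2 ug/mL. Among the three numbers measured in this assay this is the highest one; compound 3 `CN1CCN(Cc2c([O-])on[n+]2-c2ccc(Cc3ccc(-[n+]4noc([O-])c4CN4CCN(C)C(c5ccccc5)C4)cc3)cc2)CC1c1ccccc1` gives 36.8 ug/mL, a number that lies within the usual scatter of that of compound 1, while compound 2 `[O-]c1on[n+](-c2ccc(Cc3ccc(-[n+]4noc([O-])c4CN4CCCCC4)cc3)cc2)c1CN1CCCCC1` gives 12.6 ug/mL, a number beyond the scatter and lower. Compound 4 `Cc1ccc(-[n+]2noc([O-])c2CN2CCN(C)CC2)cc1` has not yet been measured. It differs from compound 1 in one place: methyl in place of 3-chlorophenyl on an amine nitrogen in a ring. Among the compounds with values here, no pair of measured compounds shows this same change, so the size of the step has to be estimated. In this assay a step of the size a 1.0-fold higher number from compound 1 to compound 4 (0.02 log units; within the scatter) is expected, which stays within the scatter. For compound 4 the expected value is 40 ug/mL, with a range from 20 ug/mL to 80 ug/mL.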

Compound 4, half-maximal cytotoxic concentration: 25.6 ug/mL
The estimate for compound 4 lay 1.6-fold (0.19 log units) above the measured number, within the range that was stated.
By their numbers in this assay, from the lowest: compound 2; then compounds 4, 3 and 1 (each within the scatter of the next).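

In this assay, putting methyl in place of 3-chlorophenyl on the amine nitrogen in the ring gives a 1.5-fold lower number from compound 1 to compound 4 (0.17 log units; within the scatter). So at this position, a large aromatic group and a single small carbon group give numbers within the usual scatter of each other, and the aromatic ring is not needed to keep the number in this range. Nothing at hand offers a reason for this. Still open, on these data alone, is how groups of other kinds on this nitrogen, such as an acetyl or a benzyl, would read here. A single step also cannot show whether the same swap would behave alike on a different core.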